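Moving the Fluorine on the Benzoyl Ring of Compound 3

The source may hold more compounds than are shown below. What is called first, only, known or untested is meant among the compounds shown, and "the series" means these compounds.

Compound 1, `Cc1cc(NC(=O)C(C)(O)C(F)(F)F)ccc1S(=O)(=O)c1ccccc1`, gives 1600 nM in a functional assay (Cavia porcellus) with sulfonylurea receptors; K-ATP channels (Homo sapiens) as the target; a lower number here means a stronger inhibitor, a higher number a weaker inhibitor. Compound 3, `CC(O)(C(=O)Nc1ccc(C(=O)c2ccccc2F)cc1)C(F)(F)F`, gives 2300 nM in this assay. Compound 2, `CC(O)(C(=O)Nc1ccc(S(=O)(=O)c2ccc([N+](=O)[O-])cc2)cc1)C(F)(F)F`, gives only a limit of the assay, > 30000 nM, in this assay (the limit of > 30000 nM in this assay, at which 1 of the 3 values shown sits).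

Compound 3 carries the higher of the two numbers shown, yet its gap to compound 1 lies within the scatter, so the two cannot be set apart. Compound 4, `CC(O)(C(=O)Nc1ccc(C(=O)c2cccc(F)c2)cc1)C(F)(F)F`, differs from compound 3 in one place: 3-fluorophenyl in place of 2-fluorophenyl on a carbonyl carbon. Among the measured compounds shown here, no measured pair shows the effect of such a shift of the fluorine, so compound 4 is expected to stay close to compound 3 in this assay, with the step of a 1.2-fold lower number from compound 3 to compound 4 (0.06 log units; within the scatter) lying within the scatter. The estimate for compound 4 in this assay is 2000 nM, in the range 800 nM to 6000 nM.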

Compound 4, half-maximal inhibitory concentration: 2600 nM
Compound 4: middle estimate off by 1.3-fold (0.11 log units), on the low side; low and high end bracket the measured number.
By their numbers in this assay, from the lowest: compounds 1, 3 and 4 (each within the scatter of the next). At a limit, above all of these: compound 2.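

Among the compounds shown here, at this place, on a carbonyl carbon, the first step that can be read in this assay is a 1.1-fold higher number from compound 3 to compound 4 (0.05 log units; within the scatter) and so 3-fluorophenyl and 2-fluorophenyl cannot be told apart here. Among the compounds shown, this shift of the fluorine therefore gives no measurable change. Nothing measured here bears on why the two stay so close. Still open, going by these compounds, is whether a phenyl carrying an amine or a carboxylic acid in place of the fluorine would shift the number beyond the scatter.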